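The compounds below may be only part of what the source reports. "The series", "measured", "known", "first", "only" and "open" are said of these compounds alone.

Measured in an ADME assay on the whole organism (Mus musculus, strain BALB/c) for pharmacokinetics, read by LC-MS, with a stated time of 24 h, at a dose of 1 mg/kg by the intravenous route; on this read-out higher numbers stand for fast clearance and lower numbers for slow clearance:
- compound 1 `O=S(=O)(Nc1ncccn1)c1ccc2c(c1)OCC[C@@H]2c1ccc(C(F)(F)F)cc1-c1ccc(F)nc1`: 2.6 mL/min/kg
- compound 2 `Cn1nccc1-c1cc(C(F)(F)F)ccc1[C@H]1CCOc2cc(S(=O)(=O)Nc3nccs3)ccc21`: 14 mL/min/kg

Compound 2 stands as the higher of the two, and its gap to compound 1 lies beyond the usual scatter. Compound 3 `Cn1nccc1-c1cc(C(F)(F)F)ccc1[C@H]1CCOc2cc(S(=O)(=O)Nc3ncccn3)ccc21` is still to be measured in this assay. It differs from compound 2 in one place: pyrimidin-2-yl in place of 1,3-thiazol-2-yl on a sulfonamide nitrogen, with pyrimidin-2-yl in place of 1,3-thiazol-2-yl on a sulfonamide nitrogen. Going by the values given here, no measured pair isolates this change. Compound 1 also carries pyrimidin-2-yl on its sulfonamide nitrogen and gives 2.6 mL/min/kg, but it differs from compound 3 elsewhere, so it is only a loose guide. A downward step of about the size of the scatter is expected, and the estimated step is a 2.0-fold lower number from compound 2 to compound 3 (0.30 log units; within the scatter). For compound 3 the estimated clearance is 7 mL/min/kg, with an expected range of 3 mL/min/kg to 16 mL/min/kg.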

Compound 3, clearance: 2.7 mL/min/kg
For compound 3 the middle estimate is 2.6-fold (0.41 log units) above the measured one; the whole stated range lies above it.
By their numbers in this assay, from the lowest: compounds 1 and 3 (each within the scatter of the next); then compound 2.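

In this assay, going by these compounds alone, pyrimidin-2-yl in place of 1,3-thiazol-2-yl on a sulfonamide nitrogen gives a 5.2-fold lower number from compound 2 to compound 3 (0.71 log units; beyond the scatter), the first direct reading of this change, and it shows that clearance responds to the group at this position while the rest of the structure stays fixed. With pyrimidin-2-yl on the sulfonamide nitrogen, 1-methyl-1H-pyrazol-5-yl in place of 6-fluoropyridin-3-yl on an aromatic carbon gives a 1.0-fold higher number from compound 1 to compound 3 (0.02 log units; within the scatter), so these two groups cannot be told apart in this read-out. No available evidence bears on the reason for the step at the sulfonamide nitrogen.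

Going by these compounds, it remains open whether the same change would give a step of similar size in compounds carrying 6-fluoropyridin-3-yl. Also open, on these data alone, is how a pyridin-2-yl or an oxazol-2-yl group on the sulfonamide nitrogen would read.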